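The source may hold more compounds than are shown below. What is called first, only, known or untested is meant among the compounds shown, and "the series" means these compounds.

Compound 1, `COCCOc1nc(N)nc2c1ncn2/C=C1/CC1(CO)CO` — in an ADME assay on BCBL1 cells (Homo sapiens) for cytotoxicity, with a stated time of 7 days (on this read-out higher numbers stand for lower toxicity in this test and lower numbers for higher toxicity in this test), compound 1 gives > 20000 nM, which is a limit of the assay and not a number.
Compound 2, `CN(C)c1nc(N)nc2c1ncn2/C=C1/CC1(CO)CO` — in this assay compound 2 gives > 20000 nM, again only a limit.
Compound 3, `CCCCCOc1nc(N)nc2c1ncn2/C=C1/CC1(CO)CO` — in this assay compound 3 gives > 20000 nM, also a limit.

All three measured compounds thus sit together at the limit of > 20000 nM in this assay, at which 3 of the 3 values shown sit. Compound 2 therefore stands at a limit, and the two further values shown are limits as well, so it cannot be ranked against compound 1 or compound 3.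

Compound 4, `CCCCNc1nc(N)nc2c1ncn2/C=C1/CC1(CO)CO`, has not yet been measured. Its difference from compound 2 is butylamino in place of dimethylamino on an aromatic carbon.

The measured steps that touch the same aromatic carbon are a step that the two limits leave unreadable from compound 1 to compound 2 and a step that the two limits leave unreadable from compound 2 to compound 3; the remaining step is a step that the two limits leave unreadable from compound 1 to compound 3. None of them has a readable size, so none gives a direction for an exchange of dimethylamino for butylamino. With every measured value at the limit, the expectation is that compound 4 also reaches the limit. The step expected from compound 2 to compound 4 is a step that the limit leaves unreadable from compound 2 to compound 4, nothing beyond the scatter. Compound 4 is accordingly estimated to give 30000 nM, with a range from 20000 nM to 100000 nM.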

Compound 4, half-maximal cytotoxic concentration: > 20000 nM
Compound 4 was reported as a limit (the forecaster's own chance of this, stated with the estimate: 85%); the middle value does not contradict the limit.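

In this assay compound 4 gives > 20000 nM, again a limit and not a number. Within the data shown here, no step between compound 4 and compound 1, compound 2 or compound 3 can therefore be read: the limit of > 20000 nM in this assay, at which 4 of the 4 values shown sit. The compounds shown leave open whether any group on this aromatic carbon would give a readable value in this assay.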